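The source may hold more compounds than are shown below. What is called first, only, known or untested is meant among the compounds shown, and "the series" means these compounds.

In a physicochemical assay for solubility, in phosphate buffer, at pH 7.4 (on this read-out lower numbers stand for lower solubility and higher numbers for higher solubility), compound 1 `CCOC(=O)c1c(-c2ccc(OC)cc2)[nH]c2cccc(OC)c2c1=O` gives > 100000 nM, which is a limit of the assay and not a number. Compound 1 therefore stands at the limit of > 100000 nM in this assay, at which 1 of the 3 values shown sits. Compound 2 `CCOC(=O)c1c(-c2ccc(C(F)(F)F)cc2)[nH]c2cc(OC)ccc2c1=O` gives 8000 nM. Compound 3 `CCOC(=O)c1c(-c2cccc(Cl)c2)[nH]c2cc(OC)ccc2c1=O` gives 58000 nM. Within the data shown here, no two of these measured compounds differ in one place only, so the series offers no measured step to carry over.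

Compound 4 `CCOC(=O)c1c(-c2cccc(OC)c2)[nH]c2cccc(OC)c2c1=O` is still unmeasured. It keeps the core of compound 1 and has 3-methoxyphenyl in place of 4-methoxyphenyl on an aromatic carbon, next to the ring nitrogen: 3-methoxyphenyl in place of 4-methoxyphenyl on an aromatic carbon. The two compounds have the same atoms, joined differently. No step beyond the usual scatter is expected in this assay, and no direction can be assigned with any confidence. The expected change is an at least 1.1-fold lower number from compound 1 to compound 4 (0.04 log units; that floor lies within the scatter). Another reading reported only as a limit is a real possibility. For compound 4 the estimated value is 90000 nM, with an expected range of 40000 nM to 160000 nM.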

Compound 4, solubility: > 100000 nM
Compound 4 was reported as a limit; the forecaster's own chance of this, stated with the estimate: 45%; middle value at least 1.1-fold (0.04 log units) away from the limit.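

In this assay compound 4 gives > 100000 nM, a limit of the assay and not a number. Compound 1 also sits at a limit, and no step can be read between compound 1 and compound 4. The compounds shown leave open whether 3-methoxyphenyl and 4-methoxyphenyl differ at all in this assay.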